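This account rests on a few compounds, and the source may have more. Where it says the series, first, only, none or still open, it means among the compounds named here.

Working notes on the series. Compound 1 `COc1ccccc1/C=C/C(=O)c1ccc(OCC(=O)N[C@H]2CCOC2=O)cc1` is the anchor here: in a functional assay on DU-145 cells (Homo sapiens) for antiproliferative activity, read by MTT assay, with a stated time of 72 h (on this read-out lower numbers stand for stronger inhibition and higher numbers for weaker inhibition), compound 1 gives 10100 nM, the lowest of the two numbers recorded. Compound 2 `O=C1OCC[C@@H]1NC(=S)SCCOc1ccccc1[N+](=O)[O-]` gives 33400 nM in this assay, a gap beyond the scatter. Compound 3 `O=C(CNc1ccc(F)cc1)N[C@H]1CCOC1=O` returns only an assay limit, > 64000 nM, in this assay; (the limit of > 64000 nM in this assay, at which 1 of the 3 values shown sits). Compound 4 `O=C(COc1ccc(C(=O)/C=C/c2ccc(Br)cc2)cc1)N[C@H]1CCOC1=O` is the next compound to be measured in this assay; it differs from compound 1 by 4-bromophenyl in place of 2-methoxyphenyl on a double-bonded chain carbon bound to a double-bonded chain carbon. Among the measured compounds shown here, no two measured compounds differ in a single place, so this step has no precedent in the set. A step of modest size is expected, near the scatter, with a lean toward a lower number. Compound 4 is estimated at 7000 nM, within a range of 2500 nM to 20000 nM. That estimate corresponds to an expected step of a 1.4-fold lower number from compound 1 to compound 4 (0.16 log units; within the scatter).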

Compound 4, half-maximal inhibitory concentration: 51700 nM
Compound 4: the middle estimate sits 7.4-fold (0.87 log units) below what was measured; the whole stated range lies below it.
By their numbers in this assay, from the lowest: compound 1; then compounds 2 and 4 (each within the scatter of the next). At a limit, above all of these: compound 3.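

In this assay, the set now holds its first single-place comparison: 4-bromophenyl in place of 2-methoxyphenyl on a double-bonded chain carbon bound to a double-bonded chain carbon gives a 5.1-fold higher number from compound 1 to compound 4 (0.71 log units; beyond the scatter). This place on the shared core is therefore not indifferent to the aryl group it carries. Nothing in the data shown accounts for this step. The swap removes the methoxy group and brings in bromine together, and the two changes cannot be separated here. On these data alone, whether plain phenyl or an aminophenyl group at this place would read closer to compound 1 or compound 4 stays open.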